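This account rests on a few compounds, and the source may have more. Where it says the series, first, only, none or still open, it means among the compounds named here.

Measured so far:
Compound 1 `CC(C)CCO[C@@H]1C=CC(=O)[C@@H](COC(=O)C(C)(C)C)O1` gives 36000 nM in an ADME assay on Vero cells (Chlorocebus sabaeus) for cytotoxicity, read by resazurin assay, with a stated time of 24 h; a higher number here means that more compound is tolerated, a lower number that less compound is tolerated.
Compound 2 `Cc1ccc(S(=O)(=O)OC[C@H]2O[C@H](OC(C)C)C=CC2=O)cc1` gives 13400 nM in this assay.

Compound 1 stands highest of the two numbers; compound 2 lies below it, and that gap is beyond the usual scatter. Compound 3 `CC(C)CO[C@@H]1C=CC(=O)[C@@H](COC(=O)C(C)(C)C)O1` differs from compound 1 in one place: isopropyl in place of isobutyl on a saturated chain carbon bound to an oxygen on a saturated carbon. Within the data shown here, no measured pair shows this change, so nothing directly guides the step; a shorter chain of this kind is expected to shift the number little, if at all, and the expected step is a 1.1-fold lower number from compound 1 to compound 3 (0.02 log units; within the scatter), none beyond the scatter. Compound 3 is therefore estimated at 34000 nM, with a range from 15000 nM to 75000 nM.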

Compound 3, half-maximal cytotoxic concentration: 28200 nM
Beside the measured number, compound 3's estimate is 1.2-fold (0.08 log units) above it; low and high end bracket the measured number.
By their numbers in this assay, from the lowest: compound 2; then compounds 3 and 1 (each within the scatter of the next).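

Among these compounds, putting isopropyl in place of isobutyl on this saturated chain carbon gives a 1.3-fold lower number from compound 1 to compound 3 (0.11 log units; within the scatter) in this assay, the only direct reading of a change at this position. The two chains therefore cannot be told apart here, and this small trim leaves the tolerated concentration within ordinary repeat variation. No supporting measurement bears on this result. On these data alone, whether the same holds for a much longer chain, such as octyl, or for a chain carrying an amine remains open.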